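Benzyl to Methyl on Selenium in Two Cytotoxicity Series

The source may hold more compounds than are shown below. What is called first, only, known or untested is meant among the compounds shown, and "the series" means these compounds.

Compound 1 `O=C(/N=C(/NC(=O)c1ccno1)[Se]Cc1ccccc1)c1ccno1` and compound 2 `C[Se]/C(=N\C(=O)c1ccno1)NC(=O)c1ccno1` share one core, while compound 3 `O=C(/N=C(/NC(=O)c1csc([N+](=O)[O-])c1)[Se]Cc1ccccc1)c1csc([N+](=O)[O-])c1` and compound 4 `C[Se]/C(=N\C(=O)c1csc([N+](=O)[O-])c1)NC(=O)c1csc([N+](=O)[O-])c1` share another; the difference between the two cores is not broken down here. In a functional assay on HT-29 cells (Homo sapiens) for cytotoxicity, read by MTT assay, with a stated time of 72 h (on this read-out higher numbers stand for lower toxicity in this test and lower numbers for higher toxicity in this test), compound 1 gives > 100000 nM, which is a limit of the assay and not a number. In this assay compound 2 also reaches only a limit, > 100000 nM. The change from compound 1 to compound 2 is hydrogen in place of phenyl on a saturated chain carbon bound to a selenium atom. Its size, a step that the two limits leave unreadable from compound 1 to compound 2, cannot be read because the limit of > 100000 nM in this assay, at which 3 of the 3 values shown sit, covers both ends of the step. In this assay compound 3 gives > 100000 nM, again a limit. Compound 4 carries the same change, at the same place: hydrogen in place of phenyl on a saturated chain carbon bound to a selenium atom. Because compound 3 sits at > 100000 nM and the earlier step that the two limits leave unreadable from compound 1 to compound 2 left no readable movement, compound 4 is expected to stay around the limit as well. Compound 4 is estimated at about 100000 nM, with an expected range from 50000 nM to 300000 nM. The step this expectation implies, a number no higher from compound 3 to compound 4 (the limit leaves the size open), is estimated to be essentially flat.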

Compound 4, concentration lethal to 50% of the cells: > 100000 nM
Compound 4: only a limit was reported (the forecaster's own chance of this, stated with the estimate: 85%); the middle value lies on the limit itself.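

The change from benzyl to methyl gives no readable step between compound 3 and compound 4, because both compounds rest on the same limit, which is not a number: the limit of > 100000 nM in this assay, at which 4 of the 4 values shown sit. The compounds shown leave open whether this change affects toxicity at all, and how the two cores compare in this assay.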